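A few compounds are considered here, and "the series" means these few. Any claim that something is new, unique, unknown or untested is made for them only; others in the source may bear on it.

Measured so far in a functional assay for antagonist activity at C-X-C chemokine receptor type 3 (Homo sapiens); a lower number here means a stronger inhibitor, a higher number a weaker inhibitor:
compound 1 `CNC(=O)c1cnc(N2CCN(C3CCN(Cc4ccc(C)cc4)CC3)[C@@H](C)C2)c(Cl)c1` gives 87 nM
compound 2 `C[C@H]1CN(c2ncc(C(=O)Nc3ccc(F)c(F)c3)cc2Cl)CCN1C1CCN(Cc2ccc(Cl)cc2)CC1` gives 22 nM
compound 3 `CNC(=O)c1cnc(N2CCN(C3CCN(Cc4ccc(Cl)cc4)CC3)C(C(=O)OC)C2)c(Cl)c1` gives 140 nM

Compound 3 gives the highest of the three numbers. Its gap to compound 1 lies within the scatter, while compound 2 sits beyond the scatter at a clearly lower number. Compound 4 `CNOC(=O)C1CN(c2ncc(C(=O)NC)cc2Cl)CCN1C1CCN(Cc2ccc(Cl)cc2)CC1` differs from compound 3 in one place: methylamino in place of methyl on an oxygen next to a carbonyl group. Among the compounds with values here, no measured pair shows this change, so the numbers give no ground for a large shift in either direction, and a step of no size beyond the scatter is the most one can expect. For compound 4 the estimated step is a 1.1-fold higher number from compound 3 to compound 4 (0.06 log units; within the scatter). For compound 4 in this assay the expected value is 160 nM, between 50 nM and 500 nM.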

Compound 4, half-maximal inhibitory concentration: 8900 nM
The estimate for compound 4 lay 56-fold (1.75 log units) below the measured number, outside the stated range (above it).
By their numbers in this assay, from the lowest: compound 2; then compounds 1 and 3 (each within the scatter of the next); then compound 4.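

In this assay, methylamino in place of methyl on an oxygen next to a carbonyl group gives a 64-fold higher number from compound 3 to compound 4 (1.80 log units; beyond the scatter). The earlier compounds shown here offered no step at this position, and this one shows that the number there can respond strongly to a small change: one added nitrogen, bringing one hydrogen-bond donor and one acceptor. Nothing available accounts for the size of this step.

The compounds shown leave open whether the added nitrogen itself matters or whether any larger group on that oxygen would do the same. An ethyl group there, or a carboxylic acid in place of the methoxycarbonyl, could separate these readings.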